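The source may hold more compounds than are shown below. What is called first, only, known or untested is meant among the compounds shown, and "the series" means these compounds.

Compound 1 `CCN(CC)CCNC(=O)c1ccc(C(CC)(CC)c2ccc(OCCC(O)(CC)CC)c(C)c2)n1CC` gives 2.3 nM in an assay on cells for agonist activity at vitamin D3 receptor (Homo sapiens), with a stated time of 96 h; a higher number here means that more compound is needed for the effect, a lower number that less compound is needed. Among the compounds with values here, compound 2 `CCC(C)C(NC(=O)c1ccc(C(CC)(CC)c2ccc(OCCC(O)(CC)CC)c(C)c2)n1CC)C(=O)O` gives 860 nM; the step of a 370-fold higher number from compound 1 to compound 2 (2.57 log units; beyond the scatter) is large, and compound 2 has the highest of the two numbers measured so far. Compound 3 `CCn1c(C(=O)NC(C)C(=O)O)ccc1C(CC)(CC)c1ccc(OCCC(O)(CC)CC)c(C)c1` keeps the acid-bearing side chain of compound 2 but carries methyl in place of sec-butyl on a saturated chain carbon bound to an amide-type nitrogen and a carbonyl carbon. Within the data shown here, no measured step bears directly on such a trimming of the side chain, and the only step known concerns a different replacement, so nothing beyond the scatter is expected in this assay. Compound 3 is therefore estimated at 900 nM, between 300 nM and 3000 nM. That estimate means a step of a 1.0-fold higher number from compound 2 to compound 3 (0.02 log units; within the scatter), which is expected to stay within the scatter.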

Compound 3, half-maximal effective concentration: 66 nM
Beside the measured number, compound 3's estimate is 14-fold (1.13 log units) above it; the measured number lies below the stated range.
By their numbers in this assay, from the lowest: compound 1; then compound 3; then compound 2.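

In this assay, the group on the saturated chain carbon bound to an amide-type nitrogen and a carbonyl carbon clearly matters: methyl in place of sec-butyl gives a 13-fold lower number from compound 2 to compound 3 (1.11 log units; beyond the scatter) in this acid-bearing series. Even so, 1-carboxyethyl in place of 2-(diethylamino)ethyl gives a 29-fold higher number from compound 1 to compound 3 (1.46 log units; beyond the scatter) and so does not recover the low number of compound 1. No evidence here accounts for either step. Still open, going by these compounds, is where a plain hydrogen or an ethyl chain at that place would fall, and how a side chain carrying an amine as well as a carboxylic acid would behave.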